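The source may report more compounds than this note shows. Statements on the series, on what has been measured and on what is new or still open speak of the compounds shown alone.

Working notes on the series in a functional assay on KYSE-510 cells (Homo sapiens) for antiproliferative activity, read by crystal violet staining, with a stated time of 96 h; on this read-out higher numbers stand for weaker inhibition of growth and lower numbers for stronger inhibition of growth. Compound 1 `O=S(=O)(NC1=NCCN1C(=S)SN1CCn2c1nsc2=S)c1ccccc1` gives >= 20000 nM in this assay, which is a limit of the assay and not a number. Compound 2 `COc1cccc(S(=O)(=O)NC2=NCCN2C(=S)SN2CCn3c2nsc3=S)c1` likewise gives >= 20000 nM in this assay, again a limit rather than a measured number. Within the data shown here, the only step measured so far, a step that the two limits leave unreadable from compound 1 to compound 2, therefore has no readable size or direction, and the limit of >= 20000 nM in this assay, at which 2 of the 2 values shown sit, is the whole of what the two values show. Compound 3 `O=S(=O)(NC1=NCCN1C(=S)SN1CCn2c1nsc2=S)c1cccc(OC(F)(F)F)c1` differs from compound 2 by trifluoromethyl in place of methyl on an oxygen on an aromatic ring. Among the measured compounds shown here, no measured step bears on this change, the single known step gives no size, and the standing of compound 2 in this assay is known only as a limit. The expectation for this assay is accordingly no step beyond the scatter that could be seen from the limit, and compound 3 is estimated to give 30000 nM, with a range from 10000 nM to 100000 nM, most likely reported again as a limit. The expected step in this assay is thus a step that the limit leaves unreadable from compound 2 to compound 3.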

Compound 3, concentration for 50% growth inhibition: >= 20000 nM
Compound 3: only a limit was reported; the forecaster's own chance of this, stated with the estimate: 85%; the middle value lies beyond the limit too.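

In this assay compound 3 gives >= 20000 nM, again a limit of the assay and not a number. Among these compounds, no step among compound 1, compound 2 and compound 3 can be read: the limit of >= 20000 nM in this assay, at which 3 of the 3 values shown sit. The compounds shown leave open whether methoxy or trifluoromethoxy in place of hydrogen changes growth inhibition at all.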